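Aryl swap on the ring amine nitrogen

This account rests on a few compounds, and the source may have more. Where it says the series, first, only, none or still open, it means among the compounds named here.

Compound 1 `Nc1scc(CN2CCN(c3cccc(Cl)c3Cl)CC2)c1C(=O)c1ccc(Cl)cc1`: -57%
Compound 2 `Nc1scc(CN2CCN(c3ccc(Cl)cc3F)CC2)c1C(=O)c1ccc(Cl)cc1`: -57%

In a functional assay on CHO cells with adenosine receptor A1 (Homo sapiens) as the target, read by cAMP accumulation and immunoassay, with a stated time of 6 min, tested at 1 uM (a lower number here means a stronger effect, a higher number a weaker effect of the compound at the concentration tested), compound 1 gives -57%, and compound 2 gives -57%. The step of no change at the digits printed from compound 1 to compound 2 (within the scatter) shows that exchanging one halogenated phenyl for another on the ring amine nitrogen left the read-out unchanged.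

Compound 3 `Nc1scc(CN2CCN(c3ccc([N+](=O)[O-])cc3)CC2)c1C(=O)c1ccc(Cl)cc1` is not yet measured. Its difference from compound 2 is 4-nitrophenyl in place of 4-chloro-2-fluorophenyl on an amine nitrogen in a ring. Going by the values given here, the only measured step bears on it indirectly, since a nitro group enters where no halogen pattern was tested. For compound 3 the expected step of a number 7 percentage points higher from compound 2 to compound 3 (within the scatter) is therefore small. Compound 3 is estimated at -50%, within -78% to -18%.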

Compound 3, a percentage reported as activity, at one concentration (the size of the read-out at that concentration, not a potency): -8.3%
Compound 3: middle estimate off by 41.7 percentage points, on the low side; measured number above the stated range.
By their numbers in this assay, from the lowest: compounds 1 and 2 (each within the scatter of the next); then compound 3.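

The aryl group on the ring amine nitrogen is not a silent position in this assay: 4-nitrophenyl gives a number 48.7 percentage points higher from compound 2 to compound 3 (beyond the scatter) and a number 48.7 percentage points higher from compound 1 to compound 3 (beyond the scatter), whereas the two halogenated phenyl groups of compound 1 and compound 2 stand level. The effect at this position therefore depends on which aryl group is present, and the halogen swap alone did not reveal this. Nothing available here accounts for the step.

Still open, on these data alone, is whether the weaker effect follows the nitro group itself or the loss of halogen. Plain phenyl, 4-aminophenyl or 4-cyanophenyl on the same nitrogen would separate the two.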